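The compounds below may be only part of what the source reports. "The series", "measured", "known", "first", "only" and "open" are said of these compounds alone.

Working notes on the series. Compound 1 `Cc1ccccc1CNc1nn(-c2ccc(F)cc2F)cc1CNCCN1CCN(C)CC1` is characterised in an ADME assay on Huh-7 cells (Homo sapiens) for cytotoxicity; on this read-out lower numbers stand for higher toxicity in this test and higher numbers for lower toxicity in this test. In this assay compound 1 gives > 20000 nM, which is a limit of the assay rather than a number. Compound 2 `Cc1ccccc1-c1nn(-c2ccccc2Cl)cc1CNCCN1CCN(C)CC1` gives > 20000 nM in this assay, again a limit. Compound 3 `Cc1ccc(-n2cc(CNCCN3CCN(C)CC3)c(-c3ccccc3C)n2)c(C)c1` gives > 20000 nM in this assay, a limit as well. The step that the two limits leave unreadable from compound 2 to compound 3 thus cannot be read in size; every measured value here sits at the limit of > 20000 nM in this assay, at which 3 of the 3 values shown sit.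

Compound 4 `Cc1ccc(-c2nn(-c3ccc(F)cc3F)cc2CNCCN2CCN(C)CC2)cc1` is not yet measured in this assay. It differs from compound 1 by 4-methylphenyl in place of (2-methylbenzyl)amino on an aromatic carbon. Among the compounds with values here, no measured step covers this change; the single measured step, from compound 2 to compound 3, concerns another place and is unreadable between two limits. The expectation for compound 4 therefore rests on (the limit of > 20000 nM in this assay, at which 3 of the 3 values shown sit), where all measured values stand. Compound 4 is expected to reach the limit too, with the step that the limit leaves unreadable from compound 1 to compound 4 estimated to lie within the scatter. Compound 4 is estimated at 30000 nM, with a range from 15000 nM to 80000 nM.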

Compound 4, half-maximal cytotoxic concentration: > 20000 nM
Compound 4: a limit, no number; the forecaster's own chance of this, stated with the estimate: 85%; the middle value does not contradict the limit.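

In this assay compound 4 gives > 20000 nM, which is a limit of the assay. Compound 1 also stands at a limit, so no step can be read between compound 1 and compound 4. The compounds shown leave open whether any structural change in the series alters this read-out, as all values remain censored: the limit of > 20000 nM in this assay, at which 4 of the 4 values shown sit.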